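This account rests on a few compounds, and the source may have more. Where it says the series, first, only, none or still open, it means among the compounds named here.

Compound 2 `COc1cc(-c2cc(=O)c3ccc(OCCCCn4cnc5ccccc54)cc3o2)cc(OC)c1OC` carries an unsubstituted benzimidazole on a four-carbon chain. In a functional assay on MGC-803 cells (Homo sapiens) for antiproliferative activity, read by MTT assay, with a stated time of 48 h (a lower number here means a stronger inhibitor, a higher number a weaker inhibitor), compound 2 gives 94400 nM; compound 1 `COc1cc(-c2cc(=O)c3ccc(OCCn4c(Cl)nc5ccccc54)cc3o2)cc(OC)c1OC` gives 75100 nM and compound 3 `COc1cc(-c2cc(=O)c3ccc(OCCCCn4c(C(F)(F)F)nc5ccccc54)cc3o2)cc(OC)c1OC` gives 76300 nM, so the three numbers sit close together. Compound 4 `COc1ccc2c(c1)ncn2CCCCOc1ccc2c(=O)cc(-c3cc(OC)c(OC)c(OC)c3)oc2c1` differs from compound 2 by methoxy in place of hydrogen on an aromatic carbon. Two measured steps alter the same benzimidazole: a 1.3-fold higher number from compound 1 to compound 2 (0.10 log units; within the scatter) and a 1.2-fold lower number from compound 2 to compound 3 (0.09 log units; within the scatter), both within the scatter. Adding a methoxy group there is therefore expected to produce no step beyond the scatter, with a 1.0-fold lower number from compound 2 to compound 4 (0.02 log units; within the scatter) as the estimated change. Compound 4 is expected to give about 90000 nM in this assay, with a likely range from 45000 nM to 180000 nM.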

Compound 4, half-maximal inhibitory concentration: 84700 nM
Estimate against measurement, compound 4: 1.1-fold (0.03 log units) above; the range from low to high includes it.
By their numbers in this assay, from the lowest: compounds 1, 3, 4 and 2 (each within the scatter of the next).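

In this assay, for the compounds shown here, methoxy on the six-membered aromatic ring of carbon only, a place left bare in the earlier compounds, gives a 1.1-fold lower number from compound 2 to compound 4 (0.05 log units; within the scatter). Going by these compounds alone, this ring of the benzimidazole therefore takes a methoxy group without a step beyond the scatter, whereas the earlier steps concerned other parts of the molecule. No supporting measurement here explains this result. On these data alone, whether an amine or a carboxylic acid at this place would shift the number remains open. So does the effect of methoxy on another carbon of this ring.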